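The compounds below may be only part of what the source reports. "The series", "measured", "known", "first", "only" and "open" are said of these compounds alone.

Measured so far in a functional assay on MCF7 cells (Homo sapiens) for inhibition, read by sulforhodamine B assay, with a stated time of 48 h; a higher number here means that more compound is tolerated, a lower number that less compound is tolerated:
compound 1 `O=C(Nc1cccc(-n2cc(-c3ccncc3)c(-c3ccc(Cl)c(O)c3)n2)c1)Nc1ccc(Cl)c(Cl)c1` — > 32500 nM
compound 2 `COc1cc(-c2nn(-c3cccc(NC(=O)c4ccccc4)c3)cc2-c2ccncc2)ccc1Cl` — > 100000 nM

Where compound 2 stands: in this assay compound 2 gives > 100000 nM, which is a limit of the assay and not a number, and it sits at the limit of > 100000 nM in this assay, at which 1 of the 2 values shown sits. Compound 1 in this assay gives > 32500 nM, likewise a limit, sitting at the limit of > 32500 nM in this assay, at which 1 of the 2 values shown sits. Both shown values are therefore limits, and no measured step between them can be stated.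

Compound 3 `COc1cc(-c2nn(-c3cccc(NC(=O)Nc4ccc(Cl)c(Cl)c4)c3)cc2-c2ccncc2)ccc1Cl` is not yet measured. Its difference from compound 2 is (3,4-dichlorophenyl)amino in place of phenyl on a carbonyl carbon, the same difference read one bond further out being benzamido to ((3,4-dichlorophenyl)carbamoyl)amino. The ((3,4-dichlorophenyl)carbamoyl)amino group of compound 3 is also that of compound 1, which gives > 32500 nM in this assay, itself a limit. The step from compound 2 to compound 3 is expected to be none beyond the scatter, an at least 1.6-fold lower number from compound 2 to compound 3 (0.22 log units; that floor lies within the scatter), with the outcome most likely again a limit. Compound 3 is estimated at 60000 nM, between 20000 nM and 200000 nM.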

Compound 3, concentration lethal to 50% of the cells: > 50000 nM
Compound 3 gave a limit, no number; the forecaster's own chance of this, stated with the estimate: 75%; the middle value is on the limit's open side.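

In this assay compound 3 gives > 50000 nM, a limit and not a number. With all values limits, the steps to compound 3 from compound 2 and from compound 1 cannot be read. Left open is where the actual values of all three compounds lie, and whether either change shifts them at all.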